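Swapping the Group on the Sulfonyl Sulfur

A few compounds are considered here, and "the series" means these few. Any claim that something is new, unique, unknown or untested is made for them only; others in the source may bear on it.

In a functional assay on LOX IMVI cells (Homo sapiens) for cytotoxicity, read by MTT assay, with a stated time of 24 h (on this read-out lower numbers stand for stronger inhibition and higher numbers for weaker inhibition), compound 1 (`O=S(=O)(NCCCNc1nccc(-c2[nH]c(-c3ccccc3)nc2-c2ccc(F)c(O)c2)n1)c1ccccc1`) gives 9580 nM, while compound 2 (`O=S(=O)(NCCCNc1nccc(-c2[nH]c(-c3ccccc3)nc2-c2ccc(F)c(O)c2)n1)c1ccc(C(F)(F)F)cc1`) gives 2450 nM, the lower of the two numbers. Compound 3 (`O=S(=O)(NCCCNc1nccc(-c2[nH]c(-c3ccccc3)nc2-c2ccc(F)c(O)c2)n1)c1cccc2ccccc12`) has not yet been measured. It carries naphthalen-1-yl in place of 4-(trifluoromethyl)phenyl on a sulfonyl sulfur. Among the measured compounds shown here, only one measured step bears on this change, a 3.9-fold lower number from compound 1 to compound 2 (0.59 log units; beyond the scatter). For the measured compounds named here, that modest step shows that altering the group on the sulfonyl sulfur can shift the number, but no measured compound carries naphthalen-1-yl, so the direction remains uncertain. A step of similar or smaller size, leaning towards a higher number, therefore seems the most reasonable expectation. The estimated step is a 1.3-fold higher number from compound 2 to compound 3 (0.12 log units; within the scatter). For compound 3, the expected value is about 3200 nM, with an estimated range of 1200 nM to 8500 nM.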

Compound 3, half-maximal inhibitory concentration: 3710 nM
Compound 3: the middle estimate sits 1.2-fold (0.06 log units) below what was measured, within the range that was stated.
By their numbers in this assay, from the lowest: compounds 2 and 3 (each within the scatter of the next); then compound 1.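

In this assay, the step of a 1.5-fold higher number from compound 2 to compound 3 (0.18 log units; within the scatter) means that naphthalen-1-yl and 4-(trifluoromethyl)phenyl cannot be told apart on the sulfonyl sulfur, even though one has two six-membered aromatic rings of carbon only and the other has one such ring and carries fluorine. The step of a 2.6-fold lower number from compound 1 to compound 3 (0.41 log units; beyond the scatter) adds a second group that gives a lower number than phenyl does, and this one contains no fluorine, so trifluoromethyl is not needed for a shift of this kind. Nothing available explains why the two groups land so close together.

As far as these compounds go, it remains open how a methyl group on the sulfonyl sulfur, with no aromatic ring at all, would compare. From the compounds shown here alone, a carboxylic acid or an amine on the phenyl ring is equally open, including whether either would move the number in the same direction.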